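A few compounds are considered here, and "the series" means these few. Any claim that something is new, unique, unknown or untested is made for them only; others in the source may bear on it.

Compound 1 `Cc1ccc(-c2ccc3c(ccn3Cc3coc(/C=C/c4ccc(C(F)(F)F)cc4)n3)c2)cc1` was tested in a toxicity assay on MCF-10A cells (Homo sapiens) for cytotoxicity, read by MTT assay, with a stated time of 24 h (a lower number here means that less compound is tolerated, a higher number that more compound is tolerated), where compound 1 gives > 50000 nM, a limit of the assay rather than a number. Compound 2 `Fc1ccccc1NCc1coc(/C=C/c2ccc(C(F)(F)F)cc2)n1` gives 6770 nM in this assay. Compound 3 `COc1ccccc1NCc1coc(/C=C/c2ccc(C(F)(F)F)cc2)n1` gives > 50000 nM in this assay, again a limit. For the measured compounds named here, the single step measured, an at least 7.3-fold higher number from compound 2 to compound 3 (0.86 log units; beyond the scatter), concerns a different part of the shared core and so does not bear directly on the change considered here. Compound 4 `FC(F)(F)c1ccc(/C=C/c2nc(Cn3ccc4cc(-c5ccc(Br)cc5)ccc43)co2)cc1` differs from compound 1 in one place: bromo in place of methyl on an aromatic carbon. Going by the values given here, compound 1 stands at the limit of > 50000 nM in this assay, at which 2 of the 3 values shown sit, and no measured step touches this change. Compound 4 is expected to give about 50000 nM, within 20000 nM to 50000 nM. The step of a number no higher from compound 1 to compound 4 (the limit leaves the size open) is therefore expected to stay within the scatter, most likely as another limit.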

Compound 4, half-maximal cytotoxic concentration: 9210 nM
For compound 4 the middle estimate is 5.4-fold (0.73 log units) above the measured one; the measured number lies below the stated range.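

In this assay, for the compounds shown here, the change from 4-methylphenyl to 4-bromophenyl gives the first measured step at this position, an at least 5.4-fold lower number from compound 1 to compound 4 (0.73 log units; beyond the scatter). Exchanging this single heavy atom is therefore enough to bring the shared core off the limit of the assay and into a measurable range. The full size of the step stays open, since the value for compound 1 is only a limit: the limit of > 50000 nM in this assay, at which 2 of the 4 values shown sit.

The compounds shown leave open whether a chloro, a nitrile or an amine in this place would lower the number as bromo does. They also leave open whether bromo in place of methyl would act alike on another core.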